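An amide swap from phenyl to ethyl and cell tolerance

The source may report more compounds than this note shows. Statements on the series, on what has been measured and on what is new or still open speak of the compounds shown alone.

compound 1, `COc1ccc(-c2cnc(NC(=O)c3ccco3)n2C)cc1`: a limit of > 100000 nM in a toxicity assay on THP-1 cells (Homo sapiens) for inhibition; a lower number here means that less compound is tolerated, a higher number that more compound is tolerated
compound 2, `COc1ccc(-c2cnc(NC(=O)c3ccc(F)cc3)n2C)cc1`: a limit of >= 50000 nM in this assay
compound 3, `COc1ccc(-c2cnc(NC(=O)c3ccccc3)n2C)cc1`: a limit of > 100000 nM in this assay

For the measured compounds named here, compound 3 stands at a limit in this assay, and the two other values are limits as well, so no compound can be placed above another. The steps a step that the two limits leave unreadable from compound 1 to compound 2, a step that the two limits leave unreadable from compound 1 to compound 3 and a step that the two limits leave unreadable from compound 2 to compound 3 all remain unreadable, as the limit of > 100000 nM in this assay, at which 2 of the 3 values shown sit, and the limit of >= 50000 nM in this assay, at which 1 of the 3 values shown sits, show.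

Compound 4, `CCC(=O)Nc1ncc(-c2ccc(OC)cc2)n1C`, differs from compound 3 by ethyl in place of phenyl on a carbonyl carbon. The three measured steps bear on it only in that every change at the carbonyl carbon so far has left the value at a limit, so no step beyond the scatter is expected in this assay in either direction, and the expected step of a number no higher from compound 3 to compound 4 (the limit leaves the size open) reflects that. For compound 4 an estimate of 100000 nM is given, within 30000 nM to 300000 nM, most likely again reported as a limit.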

Compound 4, half-maximal cytotoxic concentration: > 100000 nM
Compound 4: a limit, no number; the forecaster's own chance of this, stated with the estimate: 80%; the middle value sits exactly at the limit.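

In this assay compound 4 gives > 100000 nM, which is a limit and not a number. For the compounds shown here, no step to compound 4 from compound 1, compound 2 or compound 3 can be read. The compounds shown leave open whether any change on the carbonyl carbon alters cell tolerance.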